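The source may report more compounds than this note shows. Statements on the series, on what has been measured and on what is new or still open speak of the compounds shown alone.

Measured so far:
compound 1 `O=C(CCCCC(S)CCS)Nc1ccccc1`: 0.85%
compound 2 `O=C(CCCCC(S)CCS)Nc1ccc(Cl)cc1`: 1.06%
compound 3 `O=C(CCCCC(S)CCS)Nc1ccc(F)cc1`: "not active" (no number reported)

These three compounds share one core and differ only in the group on an aromatic carbon. All were tested in a functional assay on Bel-7402 cells (Homo sapiens) for inhibition, read by MTT assay, with a stated time of 24 h, tested at 0.1 ug/mL; on this read-out lower numbers stand for less inhibition of growth and higher numbers for more inhibition of growth at the one concentration tested. Compound 3 has no single number there. Compound 3 is recorded only as "not active" (no number reported), so it offers a description rather than a numerical starting point.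

The next compound, compound 4 `O=C(CCCCC(S)CCS)Nc1ccc(OC(F)(F)F)cc1`, keeps the shared core and carries trifluoromethoxy in place of fluoro on an aromatic carbon, para to a large group: trifluoromethoxy in place of fluoro on an aromatic carbon. Within the data shown here, only one measured step bears on this change, and only indirectly. With chloro in place of hydrogen on an aromatic carbon, the read-out moves by a number 0.2 percentage points higher from compound 1 to compound 2 (within the scatter). Among the measured compounds shown here, no measured step involves trifluoromethoxy, so the data give no direct size for this change. With so little to go on, no step beyond the scatter is expected in this assay, in either direction.

For compound 4, the expected inhibition is estimated at 2%, within an estimated range of 0% to 10%.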

Compound 4, percent growth inhibition at one concentration: "not active" (no number reported)
Compound 4: no number reported, and the estimate cannot be compared.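

In this assay, compound 3 gives "not active" (no number reported) and compound 4 gives "not active" (no number reported), so no step can be read between these two compounds. Going by these compounds, how far trifluoromethoxy or fluoro moves growth inhibition, compared with hydrogen or chloro in compound 1 and compound 2, stays open. Nothing available here offers an explanation for this result.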